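A few compounds are considered here, and "the series" means these few. Any claim that something is new, unique, unknown or untested is made for them only; others in the source may bear on it.

Compound 1 `O=c1ccoc2cc(OCc3cn(Cc4ccccc4)nn3)ccc12`: > 100000 nM
Compound 2 `O=c1ccoc2cc(OCc3cn(Cc4cccc(F)c4)nn3)ccc12`: 7550 nM

In a functional assay on HeLa cells (Homo sapiens) for cytotoxicity, read by MTT assay, with a stated time of 48 h (on this read-out higher numbers stand for weaker inhibition and lower numbers for stronger inhibition), compound 1 reaches only the limit > 100000 nM, which is not a number. Compound 2 gives 7550 nM in this assay, the only number shown. Within the data shown here, the single measured step is an at least 13-fold lower number from compound 1 to compound 2 (1.12 log units; beyond the scatter). Compound 3 `O=c1ccoc2cc(OCc3cn(Cc4cccc(Cl)c4)nn3)ccc12` is not yet measured; it differs from compound 2 by chloro in place of fluoro on an aromatic carbon. Among the measured compounds shown here, no measured step covers chloro in place of fluoro, so the step from compound 1 to compound 2 bears on it only by showing that a halogen there gives a lower number. A step within the scatter is expected: a 1.5-fold lower number from compound 2 to compound 3 (0.18 log units; within the scatter). Compound 3 is estimated at 5000 nM, between 1500 nM and 20000 nM.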

Compound 3, half-maximal inhibitory concentration: > 100000 nM
Compound 3: no number, only a limit; the forecaster's own chance of this, stated with the estimate: 5%; middle value at least 20-fold (1.30 log units) away from the limit.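

Going from 3-fluorobenzyl to 3-chlorobenzyl gives, in this assay, an at least 13-fold higher number from compound 2 to compound 3 (1.12 log units; beyond the scatter). A halogen at this place therefore does not by itself give a lower number: among the compounds shown only fluoro does, while chloro, though also a single atom, leaves only a limit. The step between compound 1 and compound 3 cannot be read, since both values are limits: the limit of > 100000 nM in this assay, at which 2 of the 3 values shown sit.

Still open, going by these compounds, is whether bromo, methyl or methoxy at this place would give a measurable number. Among these compounds, with only one real number so far, no trend across groups can be drawn.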